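From compound 1 to compound 4: a piperazin-1-yl swap

This account rests on a few compounds, and the source may have more. Where it says the series, first, only, none or still open, it means among the compounds named here.

In a functional assay on SK-BR-3 cells (Homo sapiens) for cytotoxicity, read by MTT assay, with a stated time of 72 h (on this read-out higher numbers stand for weaker inhibition and lower numbers for stronger inhibition), compound 1 (`NCCCNc1c(C(=O)NCc2ccc(F)cc2)nc(Br)c2cccnc12`) has the entry "not determined" (no result reported) and so offers no number to start from. The measured part of the series rests on two other compounds. In this assay compound 2 (`N[C@H]1CC[C@H](Nc2c(C(=O)NCc3ccc(Cl)cc3Cl)nc(Br)c3cccnc23)CC1`) gives 6000 nM as its result. In the same read-out compound 3 (`O=C(NCCCNc1c(C(=O)NCc2ccc(F)cc2)nc(Br)c2cccnc12)c1ccccc1`) gives 1000 nM as its result, a lower value than that of compound 2 by more than the usual scatter.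

Compound 4 (`O=C(NCc1ccc(F)cc1)c1nc(Br)c2cccnc2c1N1CCNCC1`) is still to be measured. The structural change is piperazin-1-yl in place of (3-aminopropyl)amino on an aromatic carbon and it sits on an aromatic carbon of the shared core, para to a bromo group, with piperazin-1-yl in place of (3-aminopropyl)amino.

With no number for compound 1, the size of this step cannot be read from the data. In this assay no step beyond the scatter is expected, and no direction is assigned. Compound 3 at 1000 nM and compound 2 at 6000 nM mark the only measured span, so the expectation rests on that span alone.

For compound 4 the estimated value is 2500 nM with an expected range from 600 nM to 10000 nM in this series.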

Compound 4, half-maximal inhibitory concentration: 6000 nM
Compound 4: middle estimate off by 2.4-fold (0.38 log units), on the low side, within the range that was stated.
By their numbers in this assay, from the lowest: compound 3; then compounds 2 and 4 (each within the scatter of the next).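

No new step can be read: in this assay compound 1 gives "not determined" (no result reported) and so compound 4 has no measured partner that differs in one place. The compounds shown leave open how the piperazin-1-yl swap shifts this read-out from a measured starting value. No evidence here bears on the result of compound 4.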